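The source may hold more compounds than are shown below. What is called first, only, known or untested is meant among the compounds shown, and "the series" means these compounds.

In an ADME assay on microsomes from liver (Mus musculus) for metabolic stability, read by LC-MS, using NADPH, with stated times of 10 min and 30 min (on this read-out lower numbers stand for slow clearance and higher numbers for fast clearance), compound 3 (`CCC(=O)N[C@@H]1CCCc2c1cncc2N1Cc2cc(Cl)ccc2C1=O`) gives < 20.2 mL/min/kg as a limit of the assay and not a number. Compound 1 (`CCC(=O)N[C@@H]1CCCc2c1cncc2N1C(=O)c2ccc(Cl)cc2[C@@H]1C`) gives < 20.2 mL/min/kg and this too is a limit. That is the limit of < 20.2 mL/min/kg in this assay, at which 2 of the 3 values shown sit, and it leaves no exact place on the scale for compound 3. Compound 2 (`CCS(=O)(=O)N[C@@H]1CCCc2c1cncc2N1Cc2cc(Cl)ccc2C1=O`) reads 27 mL/min/kg as a measured number.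

Compound 4 (`CCC(=O)N[C@@H]1CCCc2c1cncc2N1C(=O)c2ccc(Cl)cc2[C@H]1C`) carries methyl in place of hydrogen on a saturated ring carbon and this is the change to follow. Going by the values given here, the one measured step of this kind, taken in reverse, is a step that the two limits leave unreadable from compound 1 to compound 3 and it offers no size to carry over. The other step, an at least 1.3-fold lower number from compound 2 to compound 3 (0.12 log units; that floor lies within the scatter) on an amine nitrogen, does not bear on this carbon. Only a small step is expected in this assay because compound 1 with its methyl gives < 20.2 mL/min/kg as a limit. The expected step is a step that the limit leaves unreadable from compound 3 to compound 4 and it remains an estimate. Compound 4 is estimated at 18 mL/min/kg within an expected range from 10 mL/min/kg to 35 mL/min/kg.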

Compound 4, clearance: 45.6 mL/min/kg
For compound 4 the middle estimate is 2.5-fold (0.40 log units) below the measured one; measured number outside the range, above it.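

In this assay, this saturated ring carbon proved not to tolerate methyl in place of hydrogen as a matter of course, for the change gave an at least 2.2-fold higher number from compound 3 to compound 4 (0.35 log units; beyond the scatter). The same methyl drawn the other way gave an at least 2.2-fold higher number from compound 1 to compound 4 (0.35 log units; beyond the scatter), and this gap can be assigned to the drawn stereocentre alone, because nothing else separates the pair: the fact that compounds 1 and 4 differ only in the configuration as drawn. Both steps are floors and their full sizes stay unknown, because each starts from a limit: the limit of < 20.2 mL/min/kg in this assay, at which 2 of the 4 values shown sit.

As far as these compounds go, what stays open is whether a larger group on this carbon, such as ethyl, or a hydroxyl group would show the same dependence on configuration. From the compounds shown here alone, it is also open whether the configuration would matter as much with ethylsulfonyl in place of propanoyl on the amine nitrogen.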